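Swapping the sulfonyl aryl group on a fluorinated core

The compounds below may be only part of what the source reports. "The series", "measured", "known", "first", "only" and "open" are said of these compounds alone.

Compound 2 `COc1ccc(-c2c(S(=O)(=O)c3ccc(F)c(Cl)c3)cnc3cc(F)ccc23)cc1` gives 1.08 mL/min in an ADME assay on microsomes from liver (Homo sapiens) for metabolic stability, tested at 2.5 uM; a lower number here means slower removal, a higher number faster removal of the compound. Compound 1 `COc1ccc(-c2c(S(=O)(=O)c3cccc(C#N)c3)cnc3cc(F)ccc23)cc1` differs from it in one place, (3-cyanophenyl in place of 3-chloro-4-fluorophenyl on a sulfonyl sulfur), and in this assay compound 1 gives 0.92 mL/min; the step is a 1.2-fold lower number from compound 2 to compound 1 (0.07 log units; within the scatter). Compound 3 `O=S(=O)(c1ccc(F)c(Cl)c1)c1cnc2cc(F)ccc2c1-c1cccc(F)c1` keeps the sulfonyl group of compound 2 but carries a different core, (3-fluorophenyl in place of 4-methoxyphenyl on an aromatic carbon). In this assay compound 3 gives 0.25 mL/min, the lowest of the three numbers, and the step is a 4.3-fold lower number from compound 2 to compound 3 (0.64 log units; beyond the scatter).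

Compound 4 `N#Cc1cccc(S(=O)(=O)c2cnc3cc(F)ccc3c2-c2cccc(F)c2)c1` has not yet been measured in this assay. For the measured compounds named here, it differs from compound 3 by 3-cyanophenyl in place of 3-chloro-4-fluorophenyl on a sulfonyl sulfur, which is the same change, at the same place, as the one separating compound 2 from compound 1. Going by the values given here, that earlier change gave a 1.2-fold lower number from compound 2 to compound 1 (0.07 log units; within the scatter), and this is the only evidence on which an expectation can rest. On that basis the step is expected to be a 1.1-fold lower number from compound 3 to compound 4 (0.06 log units; within the scatter). Compound 4 is therefore estimated at 0.22 mL/min, with a likely range from 0.1 mL/min to 0.5 mL/min.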

Compound 4, intrinsic clearance in a liver preparation (reported as CLH), per the amount of preparation that the assay uses: 0.78 mL/min
Estimate against measurement, compound 4: 3.5-fold (0.55 log units) below; measured number above the stated range.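

In this assay, the change to 3-cyanophenyl on the sulfonyl sulfur does not carry over unchanged to the core bearing 3-fluorophenyl, where it gives a 3.1-fold higher number from compound 3 to compound 4 (0.49 log units; beyond the scatter), and the two readings of this one change do not agree: the same change on two cores in this assay, a 1.2-fold lower number (0.07 log units; within the scatter) from compound 2 to compound 1 and a 3.1-fold higher number (0.49 log units; beyond the scatter) from compound 3 to compound 4, 3.7-fold (0.56 log units) apart, beyond the scatter of two such steps. Seen from the other place, 3-fluorophenyl in place of 4-methoxyphenyl gives a 1.2-fold lower number from compound 1 to compound 4 (0.07 log units; within the scatter) with 3-cyanophenyl on the sulfonyl sulfur, and that step does not match the one seen with 3-chloro-4-fluorophenyl there: the same change on two cores in this assay, a 4.3-fold lower number (0.64 log units; beyond the scatter) from compound 2 to compound 3 and a 1.2-fold lower number (0.07 log units; within the scatter) from compound 1 to compound 4, 3.7-fold (0.56 log units) apart, beyond the scatter of two such steps. This shows that, among these four compounds, the outcome of a change at one place depends on the group at the other, but it does not show why, nor how the change would behave on any further core.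

The compounds shown leave open whether this dependence extends to other groups on the sulfonyl sulfur, such as a phenyl ring carrying an amine or a carboxylic acid. They also leave open whether an unsubstituted phenyl on the aromatic carbon would follow either core.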